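This account rests on a few compounds, and the source may have more. Where it says the series, first, only, none or still open, it means among the compounds named here.

Working notes on the series. The compounds share one core. Compound 1 `C[C@H]1CCCC[C@H]1NC(=O)c1cc2c(Cl)cc(Cl)cc2[nH]1`, compound 2 `CC1CCC(NC(=O)c2cc3c(Cl)cc(Cl)cc3[nH]2)CC1` and compound 3 `CC1CCC(NC(=O)c2cc3c(F)cc(Cl)cc3[nH]2)CC1` have been measured in a physicochemical assay for solubility, measured as thermodynamic solubility, with a stated time of 24 h, at pH 6.8; on this read-out higher numbers stand for higher solubility and lower numbers for lower solubility. In this assay compound 1 gives < 4000 nM, which is a limit of the assay and not a number. Compound 2 likewise gives only a limit, < 4000 nM. Compound 3 also gives a limit, < 4000 nM. The step that the two limits leave unreadable from compound 1 to compound 2 and the step that the two limits leave unreadable from compound 2 to compound 3 therefore remain unreadable since (the limit of < 4000 nM in this assay, at which 3 of the 3 values shown sit). Compound 4 `CC1(C)CCC(NC(=O)c2cc3c(Cl)cc(Cl)cc3[nH]2)CC1` differs from compound 2 by methyl in place of hydrogen on a saturated ring carbon. Among the compounds with values here, no measured step with a readable size bears on this change, and compound 2 itself stands only at a limit. The expectation for compound 4 is accordingly no step beyond the scatter, a step that the limit leaves unreadable from compound 2 to compound 4. Compound 4 is thus estimated at 2000 nM, within a range from 300 nM to 8000 nM.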

Compound 4, solubility: < 4000 nM
Compound 4 ended at the assay's limit; the forecaster's own chance of this, stated with the estimate: 70%; the middle value lies beyond the limit too.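

No new step can be read from compound 2 to compound 4, because compound 4 also gives only a limit: the limit of < 4000 nM in this assay, at which 4 of the 4 values shown sit. In this assay the compounds shown leave open the size of every single change among them.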